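This account rests on a few compounds, and the source may have more. Where it says the series, first, only, none or still open, it means among the compounds named here.

Measured in a functional assay on HeLa cells (Homo sapiens) for antiproliferative activity, read by MTT assay, with a stated time of 48 h; a lower number here means a stronger inhibitor, a higher number a weaker inhibitor:

- compound 1 `CNCC(=O)Nc1cc(OC)ccc1C(=O)c1ccc(OC)c2c1C=CC(C)(C)O2`: 2170 nM
- compound 2 `C=C(c1cc(OC)c(OC)c(OC)c1)c1ccc(OC)cc1NC(=O)CNC`: 140 nM

Of these two compounds, compound 2 has the lower number, at 140 nM, and so is the stronger inhibitor. The gap to compound 1, at 2170 nM, lies beyond the usual scatter of repeat measurements.

The next compound, compound 3 `C=C(c1cc(OC)c(OC)c(OC)c1)c1ccc(OC)cc1NC(=O)CN(C)C`, is built from compound 2 by one small edit: methyl in place of hydrogen on an amine nitrogen. Going by the values given here, no measured pair shows this change, so the data give no direct guide to its size or direction. With nothing to favour a rise or a fall, no shift beyond the scatter is expected in this assay, and the estimate stays anchored on compound 2 at 140 nM. The expected change is a 1.1-fold higher number from compound 2 to compound 3 (0.03 log units; within the scatter). For compound 3 the estimated value is 150 nM, with an expected range of 50 nM to 450 nM.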

Compound 3, half-maximal inhibitory concentration: 370 nM
Compound 3: the middle estimate sits 2.5-fold (0.39 log units) below what was measured; the measured number falls inside the stated range.
By their numbers in this assay, from the lowest: compound 2; then compound 3; then compound 1.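

In this assay, the amine nitrogen proves sensitive to even a small edit: replacing its hydrogen with methyl, which turns methylamino into dimethylamino, gives a 2.6-fold higher number from compound 2 to compound 3 (0.42 log units; beyond the scatter) and so a weaker inhibitor. Going by these compounds alone, this is the first direct reading of this change, and it shows that the hydrogen can be replaced at a modest cost, with a loss that still lies beyond the usual scatter. No independent measurement bears on why the number rises.

Open, on these data alone, is whether an ethyl group on this nitrogen, a ring amine such as morpholine or a plain primary amine would extend this rise or reverse it. A single step also cannot show whether the same methyl would have a similar effect on a different core.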